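A few compounds are considered here, and "the series" means these few. Any claim that something is new, unique, unknown or untested is made for them only; others in the source may bear on it.

Compound 2, `CCN(CC)CCCOc1cc2ncnc(Nc3nc4ccc(C(=O)Nc5c(C)cccc5Cl)cc4s3)c2cc1OC`, stands at the highest of the three numbers measured in a functional assay on U-937 cells (Homo sapiens) for cytotoxicity, read by WST assay, with a stated time of 72 h (on this read-out lower numbers stand for stronger inhibition and higher numbers for weaker inhibition), where compound 2 gives 7300 nM. Its nearest neighbour is compound 1, `COc1cc2c(Nc3nc4ccc(C(=O)Nc5c(C)cccc5Cl)cc4s3)ncnc2cc1OCCCN1CCCCC1C`, which in this assay gives 7000 nM; the furthest is compound 3, `CCN(CC)CCCOc1cc2ncnc(Nc3nc4ccc(C(=O)Nc5c(C)cc(C)cc5C)cc4s3)c2cc1OC`, which in this assay gives 4300 nM. Both gaps are within the scatter: a 1.0-fold higher number from compound 1 to compound 2 (0.02 log units; within the scatter) and a 1.7-fold lower number from compound 2 to compound 3 (0.23 log units; within the scatter).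

The step now followed leads to compound 4, `COc1cc2c(Nc3nc4ccc(C(=O)Nc5c(C)cccc5Cl)cc4s3)ncnc2cc1OCCCN1CCCCC1`, which differs from compound 2 by piperidin-1-yl in place of diethylamino on a saturated chain carbon, three bonds along the chain from an oxygen on an aromatic ring. Among the compounds with values here, only one measured step bears on this change, the one at the same place in the chain, a 1.0-fold higher number from compound 1 to compound 2 (0.02 log units; within the scatter), and it was flat. Since swapping the amine at the end of that three-carbon chain left the number unchanged there, compound 4 is expected to sit alongside compound 2, with a step of a 1.0-fold lower number from compound 2 to compound 4 (0.02 log units; within the scatter) that is not expected to exceed the scatter. The estimate for compound 4 is therefore 7000 nM, within a range from 3500 nM to 14000 nM.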

Compound 4, half-maximal inhibitory concentration: 8600 nM
Compound 4: middle estimate off by 1.2-fold (0.09 log units), on the low side; the measured number falls inside the stated range.
By their numbers in this assay, from the lowest: compounds 3, 1, 2 and 4 (each within the scatter of the next).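

In this assay, closing the two ethyl arms of the amine into a ring gives a 1.2-fold higher number from compound 2 to compound 4 (0.07 log units; within the scatter), so piperidin-1-yl and diethylamino cannot be told apart at this place on the chain. The methyl on the saturated ring carbon can now be read on its own, and taking it away gives a 1.2-fold higher number from compound 1 to compound 4 (0.09 log units; within the scatter), so this ring methyl also has no effect that stands clear of the scatter. All three amines at the end of the three-carbon chain thus lie within the scatter of one another, and nothing measured here offers a reason for this.

As far as these compounds go, whether a morpholine, a piperazine or a carboxylic acid at the end of the chain, or a shorter or longer chain, would move the number beyond the scatter remains open. From the compounds shown here alone, it is also open whether piperidin-1-yl would behave the same way with 2,4,6-trimethylphenyl on the amide-type nitrogen.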